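Removing a methyl from a saturated ring carbon

The source may hold more compounds than are shown below. What is called first, only, known or untested is meant among the compounds shown, and "the series" means these compounds.

Measured so far:
compound 1 `CNc1cc(C)c(C(N)=O)cn1` gives 25 nM
compound 2 `NC(=O)c1cnc2c(c1Cl)CCN2` gives 79 nM
compound 3 `C[C@@H]1Cc2cc(C(N)=O)cnc2N1` gives 38 nM

These three compounds were tested in an assay on K562 cells for inhibition of Nicotinamide N-methyltransferase (Homo sapiens), read by mass spectrometry, with a stated time of 24 h; a higher number here means a weaker inhibitor, a lower number a stronger inhibitor. Compound 3 has the second highest of the three numbers: its nearest neighbour is compound 1, whose number is lower by an amount within the scatter, and its furthest is compound 2, whose number is higher by an amount beyond the scatter. Compound 3 and compound 1 therefore cannot be told apart with confidence, while compound 2 is a weaker inhibitor than compound 3.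

The next compound, compound 4 `NC(=O)c1cnc2c(c1)CCN2`, differs from compound 3 in one place: hydrogen in place of methyl on a saturated ring carbon. In words, a hydrogen takes the place of a methyl on a saturated ring carbon. Among the measured compounds shown here, no step between two measured compounds mirrors this change, so the expected size of the step rests on the structural change alone. Losing a small carbon group usually moves the number only a little, most likely upward, and a result within the scatter would not surprise. The estimate for compound 4 is 60 nM, with a range from 25 nM to 150 nM, meaning an expected step of a 1.6-fold higher number from compound 3 to compound 4 (0.20 log units; within the scatter).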

Compound 4, half-maximal inhibitory concentration: 142 nM
Compound 4: the middle estimate sits 2.4-fold (0.37 log units) below what was measured, within the range that was stated.
By their numbers in this assay, from the lowest: compounds 1 and 3 (each within the scatter of the next); then compounds 2 and 4 (each within the scatter of the next).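

In this assay, a single methyl on this saturated ring carbon, next to the ring nitrogen, proves to matter: replacing it with hydrogen gives a 3.7-fold higher number from compound 3 to compound 4 (0.57 log units; beyond the scatter). The other one-place comparison, hydrogen in place of chloro on an aromatic carbon, gives a 1.8-fold higher number from compound 2 to compound 4 (0.25 log units; within the scatter), so compound 2 and compound 4 cannot be told apart and this chloro shows no clear effect here. No measurement shown here accounts for what the methyl does.

From the compounds shown here alone, it remains open whether an ethyl group or a longer chain on the same saturated ring carbon would lower the number further, or whether a hydroxyl group there could stand in for the methyl. Going by these compounds, the mirror-image form of the methyl compound, and a compound carrying both the methyl and the chloro, also remain open.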